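A few compounds are considered here, and "the series" means these few. Any claim that something is new, unique, unknown or untested is made for them only; others in the source may bear on it.

Compound 1 `O=C1NC(C(F)(F)F)=C(C(=O)NCCCN2CCC(c3ccc(F)cc3)CC2)[C@@H](c2ccc(F)c(F)c2)N1` gives 270 nM in an assay on LM cells with Alpha-1B adrenergic receptor (Homo sapiens) as the target; a lower number here means a stronger inhibitor, a higher number a weaker inhibitor. Compound 2 `COCC1=C(C(=O)NCCCN2CCC(c3ccc(F)cc3)CC2)[C@@H](c2ccc(F)c(F)c2)NC(=O)N1` differs from it by methoxymethyl in place of trifluoromethyl on a double-bonded ring carbon and gives 41 nM in this assay, a change that a 6.6-fold lower number from compound 1 to compound 2 (0.82 log units; beyond the scatter). Compound 3 `N#Cc1cc(F)ccc1C1CCN(CCCNC(=O)C2=C(C(F)(F)F)NC(=O)N[C@@H]2c2ccc(F)c(F)c2)CC1` differs from compound 1 by cyano in place of hydrogen on an aromatic carbon; in this assay compound 3 gives 200 nM, so that a 1.4-fold lower number from compound 1 to compound 3 (0.13 log units; within the scatter).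

Compound 4 `COCC1=C(C(=O)NCCCN2CCC(c3ccc(F)cc3C#N)CC2)[C@@H](c2ccc(F)c(F)c2)NC(=O)N1` stands to compound 3 as compound 2 stands to compound 1: the change is methoxymethyl in place of trifluoromethyl on a double-bonded ring carbon, the same change at the same place, made on a core that differs from that of compound 1 by cyano in place of hydrogen on an aromatic carbon. Because a 6.6-fold lower number from compound 1 to compound 2 (0.82 log units; beyond the scatter), a step of similar size is expected from compound 3 to compound 4, namely a 5.7-fold lower number from compound 3 to compound 4 (0.76 log units; beyond the scatter). Compound 4 is thus estimated at 35 nM in this assay, with a likely range from 15 nM to 90 nM.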

Compound 4, inhibition constant: 35 nM
Beside the measured number, compound 4's estimate shows no gap at the digits printed; low and high end bracket the measured number.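

In this assay, methoxymethyl in place of trifluoromethyl goes with a 5.7-fold lower number from compound 3 to compound 4 (0.76 log units; beyond the scatter), and this step carries over from one core to the other: the same change on two cores in this assay, a 6.6-fold lower number (0.82 log units; beyond the scatter) from compound 1 to compound 2 and a 5.7-fold lower number (0.76 log units; beyond the scatter) from compound 3 to compound 4, 1.2-fold (0.06 log units) apart, within the scatter of two such steps. Cyano in place of hydrogen on an aromatic carbon gives a 1.2-fold lower number from compound 2 to compound 4 (0.07 log units; within the scatter), which also matches the earlier step: the same change on two cores in this assay, a 1.4-fold lower number (0.13 log units; within the scatter) from compound 1 to compound 3 and a 1.2-fold lower number (0.07 log units; within the scatter) from compound 2 to compound 4, 1.2-fold (0.06 log units) apart, within the scatter of two such steps. The two changes thus combine consistently across these four compounds, but this does not show why, nor that the same would hold on any other core.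

On these data alone, whether an amine or a longer ether chain on that double-bonded ring carbon would behave alike stays open. The compounds shown also leave open how either change reads outside this assay.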